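The source may report more compounds than this note shows. Statements on the series, on what has been measured and on what is new or still open speak of the compounds shown alone.

Working notes on the series. Compound 1 (`COc1cc(/C=C/C(=O)/C=C(O)/C=C/c2ccc(OC(=O)C(C)(CO)CO)c(OC)c2)ccc1OC(=O)C(C)(CO)CO`) and compound 2 (`COc1ccc(/C=C/C(=O)/C=C(O)/C=C/c2ccc(OC)c(OC(=O)C(C)(CO)CO)c2)cc1OC(=O)C(C)(CO)CO`) both carry (1,1-bis(hydroxymethyl)ethyl)carbonyl groups on the shared core. In a functional assay on PC-3 cells (Homo sapiens) for antiproliferative activity, read by MTT assay, with a stated time of 72 h (on this read-out higher numbers stand for weaker inhibition and lower numbers for stronger inhibition), compound 1 gives 3900 nM. In this assay, compound 2 gives 4740 nM, which places compound 2 level with compound 1 within the scatter of repeated measurements.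

Compound 3 (`COc1ccc(/C=C/C(O)=C/C(=O)/C=C/c2ccc(OC)c(OC(=O)C(C)(CO)CO)c2)cc1O`) departs from compound 2 by a single change: hydrogen in place of (1,1-bis(hydroxymethyl)ethyl)carbonyl on an oxygen on an aromatic ring. This puts hydrogen in place of (1,1-bis(hydroxymethyl)ethyl)carbonyl on an oxygen on an aromatic ring. Among the measured compounds shown here, no measured compound yet shows this change on its own, so the data give no direct guide to its size.

For the measured compounds named here, the only anchor is compound 2 at 4740 nM. In this assay, the expected outcome is a small step, leaning slightly towards weaker inhibition and most likely not beyond the scatter. The estimated move is a 1.2-fold higher number from compound 2 to compound 3 (0.06 log units; within the scatter). For compound 3 the expected value is 5500 nM, with an estimated range of 2200 nM to 13000 nM.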

Compound 3, half-maximal inhibitory concentration: 2320 nM
Compound 3: the middle estimate sits 2.4-fold (0.37 log units) above what was measured, and the stated range covers the measured number.
By their numbers in this assay, from the lowest: compounds 3, 1 and 2 (each within the scatter of the next, the first and the last beyond it).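

In this assay, among the compounds shown here, taking the (1,1-bis(hydroxymethyl)ethyl)carbonyl group off an oxygen on an aromatic ring and leaving hydroxy gives a 2.0-fold lower number from compound 2 to compound 3 (0.31 log units; beyond the scatter), the first single change that can be read. At this position the group is therefore not needed for the antiproliferative activity seen here, and the free hydroxy gives a modest gain in inhibition rather than a loss, though this rests on one pair in which compound 3 keeps its second (1,1-bis(hydroxymethyl)ethyl)carbonyl group. No available measurement explains the size or direction of this step.

From the compounds shown here alone, it remains open whether the same change at the second substituted oxygen, or at both oxygens together, would move the number in the same direction. Going by these compounds, it is also open whether a different group on this oxygen, such as a methyl ether, an acetyl ester, or a longer acyl chain ending in an amine, would retain or extend the gain seen with hydroxy.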